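Amide-nitrogen substituent change in the benzoxazinone series

This account rests on a few compounds, and the source may have more. Where it says the series, first, only, none or still open, it means among the compounds named here.

The shared core of compound 1 `O=C1COc2ccc(-c3cnc4ccccc4c3)cc2N1c1ccccc1` and compound 2 `O=C1COc2ccc(-c3ccc(O)cc3)cc2N1` carries a cyclic amide nitrogen and a biaryl linkage. In a functional assay on HeLa cells (Homo sapiens) for antiproliferative activity, read by MTT assay, with a stated time of 72 h (on this read-out higher numbers stand for weaker inhibition and lower numbers for stronger inhibition), compound 1 gives > 40000 nM, a limit of the assay rather than a number. In this assay compound 2 likewise gives > 40000 nM, again a limit. Two of the three recorded values therefore sit at the upper boundary of the assay (the limit of > 40000 nM in this assay, at which 2 of the 3 values shown sit). Among the measured compounds shown here, compound 3 `COc1ncc(-c2ccc3c(c2)N(c2ccc(F)cc2)C(=O)CO3)cc1NS(=O)(=O)c1ccc(F)cc1` is the one member with a measured number: in this assay compound 3 gives 10500 nM, so it alone can anchor any comparison within the set.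

Compound 4 `COc1ncc(-c2ccc3c(c2)N(C(C)C)C(=O)CO3)cc1NS(=O)(=O)c1ccc(F)cc1` differs from compound 3 in a single place (isopropyl in place of 4-fluorophenyl on an amide-type nitrogen in a ring). For the measured compounds named here, no measured step of this kind exists in the set, so the size and direction of the change are open. The expectation is a modest weakening from compound 3 to compound 4, a 1.5-fold higher number from compound 3 to compound 4 (0.18 log units; within the scatter), though a result within the scatter of compound 3 at 10500 nM is also plausible. Compound 4 is estimated at 16000 nM in this assay, with a range from 5000 nM to 45000 nM, and a real chance that only a limit is reported.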

Compound 4, half-maximal inhibitory concentration: 2790 nM
Estimate against measurement, compound 4: 5.7-fold (0.76 log units) above; measured number below the stated range.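

The amide-type nitrogen in a ring now has a measured step in this assay: isopropyl in place of 4-fluorophenyl gives a 3.8-fold lower number from compound 3 to compound 4 (0.58 log units; beyond the scatter) and thus the stronger read-out of the pair. In this pair, the aromatic ring on this nitrogen is not needed for activity, and the smaller group with no ring does better. Nothing shown gives a cause for this step, and the single pair cannot separate the loss of the ring from the change in size.

Among the compounds shown here, only two groups on this nitrogen carry numbers, so the trend remains undefined for a methyl group, a longer chain such as n-butyl, or a chain ending in an amine. Compound 1 and compound 2 differ from compound 4 in more than one place and add nothing to this step.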